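Swapping a benzyl for an ester on a triazole nitrogen

The compounds below may be only part of what the source reports. "The series", "measured", "known", "first", "only" and "open" are said of these compounds alone.

Compound 1, `CC(=O)OCCn1cc(-c2cccc(NC(=O)c3cn(Cc4ccccc4)nn3)c2)nn1`, gives 25100 nM in a functional assay on B16 cells (Mus musculus) for cytotoxicity, read by MTT assay, with a stated time of 48 h; on this read-out higher numbers stand for weaker inhibition and lower numbers for stronger inhibition.
Compound 2, `CCOC(=O)Cn1cc(C(=O)Nc2cccc(-c3cn(CCOC(C)=O)nn3)c2)nn1`, reaches only a limit of the assay, > 100000 nM, in this assay.
Compound 3, `O=C(Nc1ccccc1)c1cn(Cc2ccccc2)nn1`, gives 93000 nM in this assay.

Compound 1 and compound 2 share one core and differ in a single place: ethoxycarbonyl in place of phenyl on a saturated chain carbon bound to an aromatic nitrogen. That change produced an at least 3.9-fold higher number from compound 1 to compound 2 (0.60 log units; beyond the scatter), a step that can only be bounded because of the limit of > 100000 nM in this assay, at which 1 of the 3 values shown sits. Compound 3 carries a smaller core; how its core differs from that of compound 1 is not broken down here, and the two values simply show that compound 3 gives the higher number of the two.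

Compound 4, `CCOC(=O)Cn1cc(C(=O)Nc2ccccc2)nn1`, is made from compound 3 by the same change, (ethoxycarbonyl in place of phenyl on a saturated chain carbon bound to an aromatic nitrogen). For compound 4 the expected step is a 3.2-fold higher number from compound 3 to compound 4 (0.51 log units; beyond the scatter), which rests on the measured step of an at least 3.9-fold higher number from compound 1 to compound 2 (0.60 log units; beyond the scatter). Compound 4 is therefore expected to land near 300000 nM in this assay, with a plausible range of 100000 nM to 1000000 nM, and most likely the assay will report only a limit for it.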

Compound 4, half-maximal inhibitory concentration: > 100000 nM
Compound 4 was reported as a limit; the forecaster's own chance of this, stated with the estimate: 85%; the middle value does not contradict the limit.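

Compound 4 gives > 100000 nM in this assay as a limit of the assay, not a number. The step on the smaller core can therefore be read only as an at least 1.0-fold higher number from compound 3 to compound 4 (0.03 log units; that floor lies within the scatter), which neither confirms nor excludes a real rise there, so the change cannot be said to carry over with the same size, and the comparison of the two cores stays as follows: the same change on two cores in this assay, an at least 3.9-fold higher number (0.60 log units; beyond the scatter) from compound 1 to compound 2 and an at least 1.0-fold higher number (0.03 log units; that floor lies within the scatter) from compound 3 to compound 4; the limit leaves it open whether they differ
Neither core gives a lower number after the change, yet no exact size can be given for it on either core because of this: the limit of > 100000 nM in this assay, at which 2 of the 4 values shown sit.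

The compounds shown hold only phenyl and ethoxycarbonyl on the saturated chain carbon bound to an aromatic nitrogen, so what an amine or a carboxylic acid in that place would do stays open. Also open, as far as these compounds go, is the true size of the step on either core, which would take a compound carrying ethoxycarbonyl that gives a number rather than a limit.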